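Thioester in place of ester on a carbamate

This account rests on a few compounds, and the source may have more. Where it says the series, first, only, none or still open, it means among the compounds named here.

Measured compounds:
compound 1 `CC(C)OC(=O)N1CCC(Oc2cccc3c2CCN3c2ccc(S(C)(=O)=O)cc2F)CC1` gives 62%
compound 2 `CC(C)OC(=O)N1CCC(Oc2ncnc3c2CCN3c2ccc(-c3nccs3)cc2F)CC1` gives 74%
compound 3 `CCOC(=O)N1CCC(Oc2ncnc3c2CCN3c2ccc(S(C)(=O)=O)cc2F)CC1` gives 135%

The read-out throughout is a functional assay on CHO-K1 cells with Glucose-dependent insulinotropic receptor (Homo sapiens) as the target, read by a luciferase reporter, with a stated time of 5 h; on this read-out higher numbers stand for larger maximal responses and lower numbers for smaller maximal responses. Compound 3 stands highest of the three measured compounds: its value lies well beyond the scatter above both compound 2 and compound 1. Among the compounds with values here, compounds 1 and 2 each differ from compound 3 in more than one place, so their numbers only show where they lie; no single-change step connects any pair of the measured compounds.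

Compound 4 `CC(C)SC(=O)N1CCC(Oc2ncnc3c2CCN3c2ccc(S(C)(=O)=O)cc2F)CC1` is not yet measured. It differs from compound 3 in one place: isopropylsulfanyl in place of ethoxy on a carbonyl carbon. Within the data shown here, nothing measured here shows what this change does, since no pair of measured compounds carries it. The large value of compound 3 leaves room for a fall, and the other two compounds show that this core region can also sit far lower.

A moderate decrease for compound 4 is therefore expected, with wide uncertainty, as the step of a number 30 percentage points lower from compound 3 to compound 4 (beyond the scatter) in this assay. Compound 4 is estimated at 105%, expected to fall between 65% and 145%.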

Compound 4, largest response reached (reported as percent of maximum), in percent of the reference or control that the assay uses: 138%
Estimate against measurement, compound 4: 33 percentage points below; measured number inside the range.
By their numbers in this assay, from the lowest: compound 1; then compound 2; then compounds 3 and 4 (each within the scatter of the next).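

Isopropylsulfanyl in place of ethoxy on a carbonyl carbon is the first single-place step available in this series, and in this assay it reads as a number 3 percentage points higher from compound 3 to compound 4 (within the scatter). Within the data shown here, the large maximal response therefore holds when the group on this carbonyl carbon, whose other neighbour is an amide-type nitrogen in a ring, gains a carbon, has its oxygen replaced by sulfur and takes on a branched chain, which the earlier compounds could not show because none of them were linked by a single change. Nothing measured alongside these compounds explains why the response holds at this position.

The swap alters the linking atom and the chain together, so the contribution of each stays unresolved: ethylsulfanyl on the same carbonyl carbon would keep the sulfur with the shorter chain and separate the two. As far as these compounds go, how far this position stretches also remains open, including whether a longer chain such as hexylsulfanyl or an amine such as dimethylamino would keep the response as high.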